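The compounds below may be only part of what the source reports. "The series", "measured", "known", "first", "only" and "open" are said of these compounds alone.

Measured so far in a functional assay on CHO cells for agonist activity at Alpha-1A adrenergic receptor (Homo sapiens), read by FLIPR and calcium flux; a lower number here means that less compound is needed, a higher number that more compound is needed for the effect:
compound 1 `Cn1cc(-c2cccc3c2CCC3c2ncc[nH]2)cn1` – > 2900 nM
compound 2 `COc1c(C)ccc2c1CCC2c1ncc[nH]1` – 167 nM

Compound 1 has no numeric value in this assay; its entry is a limit of the assay, (the limit of > 2900 nM in this assay, at which 1 of the 2 values shown sits). For the measured compounds named here, compound 2 gives 167 nM in this assay, but compound 1 and compound 2 differ in more than one place and no step between them is available, so their two values can only be set side by side.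

Compound 3 `c1cncc(-c2cccc3c2CCC3c2ncc[nH]2)c1` is not yet measured. It differs from compound 1 in one place: pyridin-3-yl in place of 1-methyl-1H-pyrazol-4-yl on an aromatic carbon. One small aromatic ring is exchanged for another at the same place on the core; the rest of compound 1 is kept. Going by the values given here, since compound 1 sits at a limit, no measured step anchors the change, and the limit leaves room for compound 3 to fall on either side of it.

Compound 3 is expected near 4000 nM, with a range of 800 nM to 20000 nM. The step that the limit leaves unreadable from compound 1 to compound 3 is expected to be small, not clearly beyond the scatter, and a further limit-only result for compound 3 is a real possibility.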

Compound 3, half-maximal effective concentration: 2060 nM
The estimate for compound 3 lay 1.9-fold (0.29 log units) above the measured number; the range from low to high includes it.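

With compound 3, this aromatic carbon of the shared core carries a six-membered aromatic ring and gives a numeric reading in this assay: compound 3 gives 2060 nM, where the only earlier entry for this place was not a number. Exchanging 1-methyl-1H-pyrazol-4-yl for pyridin-3-yl gives an at least 1.4-fold lower number from compound 1 to compound 3 (0.14 log units; that floor lies within the scatter), so only a floor for the step is known, and that floor does not separate the two aromatic rings in this assay. The entry for compound 1 is a limit of the assay, and the true size of the step cannot be read from it: the limit of > 2900 nM in this assay, at which 1 of the 3 values shown sits.

The compounds shown leave open how a phenyl ring without a ring nitrogen, or a non-aromatic group such as an amine or a carboxylic acid, would read on this same carbon. Also open is whether the place of the nitrogen within the ring matters, as pyridin-3-yl is the only pyridine ring among these compounds.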